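Amide aryl swap on a dimethoxy core: the pyridyl case

A few compounds are considered here, and "the series" means these few. Any claim that something is new, unique, unknown or untested is made for them only; others in the source may bear on it.

Measured compounds:
compound 1, `COc1cc2c(cc1OC)C(CC(=O)Nc1cccc(Cl)c1)CC2`, 63.3%
compound 2, `COc1cc2c(cc1OC)C(CC(=O)Nc1ccc(C)cc1)CC2`, 30%

The two measured compounds share one core and differ only in the ring on the amide-type nitrogen. In a functional assay on the whole organism (strain Wistar) for inhibition, with Rattus norvegicus as the target, read by paw edema, with a stated time of 24 h, at a dose of 100 mg/kg (on this read-out higher numbers stand for more inhibition at the one dose given (going by the name of the read-out) and lower numbers for less inhibition), compound 1 gives 63.3%, the higher of the two numbers. The one measured step is a number 33.3 percentage points lower from compound 1 to compound 2 (beyond the scatter), a change well beyond the scatter, so exchanging the ring on this nitrogen has been shown to move the read-out strongly.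

Compound 3, `COc1cc2c(cc1OC)C(CC(=O)Nc1ccccn1)CC2`, has not yet been measured. It differs from compound 1 by pyridin-2-yl in place of 3-chlorophenyl on an amide-type nitrogen. Within the data shown here, the only step that bears on this is the one from compound 1 to compound 2, where a different aryl ring on the same nitrogen lowered the read-out by a large margin. Among the measured compounds shown here, no measured pair contains a pyridin-2-yl group, so the direction is taken only from that single precedent. A downward step in this assay is therefore expected, though its size is uncertain.

Compound 3 is estimated to give 42%, within 20% to 62%, which means an expected step of a number 21.3 percentage points lower from compound 1 to compound 3 (beyond the scatter).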

Compound 3, a percentage reported as inhibition, in the whole organism at one dose (the size of the read-out at that dose, not a potency): 33.3%
Estimate against measurement, compound 3: 8.7 percentage points above, within the range that was stated.
By their numbers in this assay, from the lowest: compounds 2 and 3 (each within the scatter of the next); then compound 1.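

With pyridin-2-yl in place of 3-chlorophenyl on the amide-type nitrogen, this assay gives a number 30 percentage points lower from compound 1 to compound 3 (beyond the scatter), so the loss seen earlier is no longer tied to 4-methylphenyl alone: two different replacement rings now fall well short of the 3-chlorophenyl compound. The two replacements themselves cannot be told apart, with a number 3.3 percentage points higher from compound 2 to compound 3 (within the scatter), even though one is a ring of carbon only and the other carries a ring nitrogen and a hydrogen-bond acceptor; among these three compounds, the presence of that ring nitrogen therefore makes no visible difference against 4-methylphenyl. Nothing measured here accounts for the gap between 3-chlorophenyl and the other two rings.

From the compounds shown here alone, it remains open whether the higher number goes with the chlorine itself or with where it sits on the ring, a question that a plain phenyl, a 4-chlorophenyl or a 3-methylphenyl group on the same nitrogen would help to settle. A pyridin-3-yl or pyridin-4-yl group would likewise show whether the place of the ring nitrogen matters, and all of these readings rest on a single dose and a single time.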